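Cyano to phenyl on the pyridyl ether core

The compounds below may be only part of what the source reports. "The series", "measured", "known", "first", "only" and "open" are said of these compounds alone.

Measured compounds in an assay on brain for binding affinity to Neuronal acetylcholine receptor; alpha4/beta2 (Rattus norvegicus), read by radioligand binding; on this read-out lower numbers stand for stronger inhibition and higher numbers for weaker inhibition:
compound 1 `C=Cc1ccc(OC[C@@H]2CCN2)cn1` gives 1.25 nM
compound 2 `c1ccc(-c2ccc(OC[C@@H]3CCN3)cn2)cc1` gives 2.3 nM
compound 3 `N#Cc1cncc(OC[C@@H]2CCN2)c1` gives 0.025 nM

Compound 3 stands lowest of the three numbers in this assay, beyond the scatter from both compound 1 and compound 2, which lie within the scatter of each other.

Compound 4 `c1ccc(-c2cncc(OC[C@@H]3CCN3)c2)cc1` differs from compound 3 as follows: phenyl in place of cyano on an aromatic carbon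

For the measured compounds named here, the only measured step with phenyl entering, a 1.8-fold higher number from compound 1 to compound 2 (0.26 log units; within the scatter), was within the scatter, but there phenyl replaced vinyl on a different core; no measured step removes cyano. Given the values of compound 3 and compound 1, the cyano appears tied to the low number, so a step toward higher numbers is expected, estimated as a 20-fold higher number from compound 3 to compound 4 (1.30 log units; beyond the scatter). Compound 4 is therefore expected at about 0.5 nM, within 0.1 nM to 3 nM.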

Compound 4, inhibition constant: 0.046 nM
Beside the measured number, compound 4's estimate is 11-fold (1.04 log units) above it; measured number below the stated range.
By their numbers in this assay, from the lowest: compounds 3 and 4 (each within the scatter of the next); then compounds 1 and 2 (each within the scatter of the next).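

The change in this assay gives a 1.8-fold higher number from compound 3 to compound 4 (0.26 log units; within the scatter) and so shows that, on this aromatic carbon two atoms from the ring nitrogen, a low number does not depend on the cyano. Phenyl, with one six-membered aromatic ring of carbon only and 0 hydrogen-bond acceptors, takes the place of cyano with no step beyond the scatter. No evidence at hand explains why the two groups read alike.

Open, from the compounds shown here alone, is whether an amine, a carboxylic acid or a longer chain on this carbon would hold the number. Also open, going by these compounds, is whether a methoxy group on the phenyl would do so.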